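Piperidin-1-yl for methylsulfanyl on the shared core

A few compounds are considered here, and "the series" means these few. Any claim that something is new, unique, unknown or untested is made for them only; others in the source may bear on it.

In an ADME assay on L6 cells (Rattus norvegicus) for cytotoxicity (on this read-out higher numbers stand for weaker inhibition and lower numbers for stronger inhibition), compound 1 `Nc1ccc(NC2=NCCN2)cc1` reports only a limit, > 423000 nM.

Among the compounds with values here, compound 2 `CSc1ccc(NC2=NCCN2)cc1` gives 174000 nM, the only actual number so far.

Compound 3 `c1cc(N2CCCCC2)ccc1NC1=NCCN1` follows from compound 2 by piperidin-1-yl in place of methylsulfanyl on an aromatic carbon, with piperidin-1-yl in place of methylsulfanyl on an aromatic carbon.

Within the data shown here, the one measured step at this carbon is an at least 2.4-fold lower number from compound 1 to compound 2 (0.38 log units; beyond the scatter), and it sets the modest size expected here.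

A further move to a lower number is expected, estimated as a 2.5-fold lower number from compound 2 to compound 3 (0.40 log units; beyond the scatter).

For compound 3 the estimate is 70000 nM, with an expected range of 20000 nM to 200000 nM.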

Compound 3, half-maximal inhibitory concentration: > 283000 nM
Compound 3 was reported as a limit; the forecaster's own chance of this, stated with the estimate: 5%; middle value at least 4.0-fold (0.60 log units) from the limit.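

In this assay, piperidin-1-yl on this aromatic carbon does not carry on the move to a lower number seen with methylsulfanyl: the step reads an at least 1.6-fold higher number from compound 2 to compound 3 (0.21 log units; that floor lies within the scatter). Within the data shown here, compound 3 gives only a limit, > 283000 nM, so compound 2 remains the only actual number. The step from compound 1 to compound 3 joins two limits and cannot be read.

As far as these compounds go, how far compound 3 really lies from compound 2 stays open. Also open, from the compounds shown here alone, is how a smaller amine such as dimethylamino, or a morpholin-4-yl ring, would read on this carbon.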